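Compound 4: a larger amine on the shared core

The source may report more compounds than this note shows. Statements on the series, on what has been measured and on what is new or still open speak of the compounds shown alone.

Three measured compounds share one core and differ only in the amine on a saturated chain carbon, three bonds along the chain from an oxygen on an aromatic ring. In a functional assay on MCF7 cells (Homo sapiens) for antiproliferative activity (a lower number here means a stronger inhibitor, a higher number a weaker inhibitor), compound 1 `CC(C)=CCc1cc(C(=O)Nc2cc3ccc(OCCCNCC(C)C)c(C)c3oc2=O)ccc1O` gives 1320 nM, compound 2 `CC(C)=CCc1cc(C(=O)Nc2cc3ccc(OCCCN(C)C(C)C)c(C)c3oc2=O)ccc1O` gives 1050 nM, and compound 3 `CC(C)=CCc1cc(C(=O)Nc2cc3ccc(OCCCNC(C)(C)C)c(C)c3oc2=O)ccc1O` gives 950 nM. Compound 2 holds the second highest number of the three, nearest to compound 3 and furthest from compound 1, both within the scatter.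

Compound 4 `CC(C)=CCc1cc(C(=O)Nc2cc3ccc(OCCCN[C@@H]4C[C@H]5CC[C@@H]4C5)c(C)c3oc2=O)ccc1O` differs from compound 2 in this way: a group of 8 heavy atoms (7 carbon, 1 nitrogen; 2 five-membered non-aromatic rings of carbon only) in place of a group of 5 heavy atoms (4 carbon, 1 nitrogen; no ring), on a saturated chain carbon, three bonds along the chain from an oxygen on an aromatic ring. Going by the values given here, the steps that bear on it, a 1.3-fold lower number from compound 1 to compound 2 (0.10 log units; within the scatter) and a 1.1-fold lower number from compound 2 to compound 3 (0.04 log units; within the scatter), both changed the same amine and both stayed within the scatter. The expected step is therefore a 1.2-fold lower number from compound 2 to compound 4 (0.07 log units; within the scatter), within the scatter. Compound 4 is estimated at 900 nM, with a range from 400 nM to 2000 nM.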

Compound 4, half-maximal inhibitory concentration: 1030 nM
Compound 4: middle estimate off by 1.1-fold (0.06 log units), on the low side; measured number inside the range.
By their numbers in this assay, from the lowest: compounds 3, 4, 2 and 1 (each within the scatter of the next).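

In this assay compound 4, with its two five-membered non-aromatic rings of carbon only, stands within the scatter of all three earlier compounds: a 1.0-fold lower number from compound 2 to compound 4 (0.01 log units; within the scatter), a 1.1-fold higher number from compound 3 to compound 4 (0.04 log units; within the scatter) and a 1.3-fold lower number from compound 1 to compound 4 (0.11 log units; within the scatter). The amine on this saturated chain carbon, three bonds along the chain from an oxygen on an aromatic ring, can thus carry these rings, not only the open-chain groups of compounds 1, 2 and 3, with no step beyond the scatter. No supporting measurement accounts for this result. The compounds shown leave open whether a carboxylic acid in place of the amine, or a longer chain leading to it, would give a step beyond the scatter.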